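From a Limit Value to a Naphthalen-1-yl Analogue

The source may report more compounds than this note shows. Statements on the series, on what has been measured and on what is new or still open speak of the compounds shown alone.

In an ADME assay on A549 cells (Homo sapiens) for cytotoxicity, read by CellTiter-Glo (on this read-out higher numbers stand for lower toxicity in this test and lower numbers for higher toxicity in this test), compound 3 `COC(=O)c1ccc(Cc2c(C)c3ccc(OCC(O)CN4CCC(C(N)=O)CC4)cc3oc2=O)cc1` gives > 100000 nM, which is a limit of the assay and not a number. Compound 1 `Cc1c(Cc2cccc(F)c2)c(=O)oc2cc(OCC(O)CN3CCC(C(N)=O)CC3)ccc12` gives 53300 nM and compound 2 `Cc1c(Cc2ccc(F)cc2Cl)c(=O)oc2cc(OCC(O)CN3CCC(C(N)=O)CC3)ccc12` gives 90800 nM. Exchanging their aryl groups gives a 1.7-fold higher number from compound 1 to compound 2 (0.23 log units; within the scatter). Compound 4 `Cc1c(Cc2cccc3ccccc23)c(=O)oc2cc(OCC(O)CN3CCC(C(N)=O)CC3)ccc12` differs from compound 3 as follows: naphthalen-1-yl in place of 4-(methoxycarbonyl)phenyl on a saturated chain carbon bound to an aromatic carbon. Two measured steps change the group at this same place, namely an at least 1.8-fold higher number from compound 1 to compound 3 (0.27 log units; that floor lies within the scatter) and an at least 1.1-fold higher number from compound 2 to compound 3 (0.04 log units; that floor lies within the scatter). Both are only floors. With the 4-(methoxycarbonyl)phenyl gone, compound 4 is expected to sit near compound 2 at 90800 nM and compound 1 at 53300 nM. The expected change is an at least 1.6-fold lower number from compound 3 to compound 4 (0.22 log units; that floor lies within the scatter), a modest move towards a lower number. For compound 4 the estimated value is 60000 nM, with an expected range of 25000 nM to 100000 nM.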

Compound 4, half-maximal cytotoxic concentration: 42400 nM
Beside the measured number, compound 4's estimate is 1.4-fold (0.15 log units) above it, within the range that was stated.
By their numbers in this assay, from the lowest: compounds 4, 1 and 2 (each within the scatter of the next, the first and the last beyond it). At a limit, above all of these: compound 3.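

In this assay, among the compounds shown here, naphthalen-1-yl gives the first steps at this place, on a saturated chain carbon bound to an aromatic carbon, that are printed as beyond the scatter (an at least 2.3-fold lower number from compound 3 to compound 4 (0.37 log units; beyond the scatter); a 2.1-fold lower number from compound 2 to compound 4 (0.33 log units; beyond the scatter)). Against 3-fluorophenyl the same group stays within the scatter (a 1.3-fold lower number from compound 1 to compound 4 (0.10 log units; within the scatter)), so these two aryl groups are not told apart here. The step from compound 3 is only a floor, since compound 3 stands at a limit of the assay and not at a number: (the limit of > 100000 nM in this assay, at which 1 of the 4 values shown sits).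

The compounds shown leave open how an aryl group carrying a carboxylic acid or an amine would read in this assay at this place.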